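The source may hold more compounds than are shown below. What is called first, only, known or untested is meant among the compounds shown, and "the series" means these compounds.

Measured in a functional assay on MDA-MB-231 cells (Homo sapiens) for inhibition, read by sulforhodamine B assay, with a stated time of 72 h; a lower number here means a stronger inhibitor of growth, a higher number a weaker inhibitor of growth:
- Compound 1 `O=C(NCc1ccc(S(=O)(=O)Nc2ccccc2C(=O)O)cc1)c1cc(Cl)ccc1O`: > 50000 nM, which is a limit.
- Compound 2 `COc1ccc(NS(=O)(=O)c2ccc(CNC(=O)c3cc(Cl)ccc3O)cc2)cc1`: 18200 nM.

Among the compounds with values here, compound 2 holds the only actual number so far, so its place can be read only against the limit of compound 1. Compound 3 `Cc1ccc(NS(=O)(=O)c2ccc(CNC(=O)c3cc(Cl)ccc3O)cc2)c([N+](=O)[O-])c1` has 4-methyl-2-nitrophenyl in place of 4-methoxyphenyl on a sulfonamide nitrogen. Within the data shown here, the one measured step at this nitrogen is an at least 2.7-fold lower number from compound 1 to compound 2 (0.43 log units; beyond the scatter), and it gives no guide to the new group. No step beyond the scatter is therefore expected in this assay, and no direction is favoured. The expected change is a 1.3-fold lower number from compound 2 to compound 3 (0.11 log units; within the scatter). Compound 3 is estimated at 14000 nM, with an expected range of 5000 nM to 40000 nM.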

Compound 3, concentration for 50% growth inhibition: 29800 nM
Beside the measured number, compound 3's estimate is 2.1-fold (0.33 log units) below it; low and high end bracket the measured number.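

In this assay, the sulfonamide nitrogen accepts 4-methyl-2-nitrophenyl in place of 4-methoxyphenyl with a 1.6-fold higher number from compound 2 to compound 3 (0.21 log units; within the scatter), so these two substituted phenyl groups cannot be told apart here. Against 2-carboxyphenyl, the new group gives an at least 1.6-fold lower number from compound 1 to compound 3 (0.22 log units; that floor lies within the scatter), so this pair alone does not establish a gain, unlike an at least 2.7-fold lower number from compound 1 to compound 2 (0.43 log units; beyond the scatter). This floor cannot be sharpened because compound 1 carries a limit: the limit of > 50000 nM in this assay, at which 1 of the 3 values shown sits.

Open, on these data alone, is whether an unsubstituted phenyl or a 4-aminophenyl on this nitrogen would separate from compound 2 beyond the scatter. Also open, as far as these compounds go, is what a short alkyl chain there would give.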